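Removing the methyl from the methoxy group of compound 2

This account rests on a few compounds, and the source may have more. Where it says the series, first, only, none or still open, it means among the compounds named here.

Measured compounds:
compound 1 `O=C(Nc1cccc(-n2cc(-c3ccncc3)c(-c3ccc(Cl)c(O)c3)n2)c1)Nc1cccc(C(F)(F)F)c1`, 20100 nM
compound 2 `COc1cc(-c2nn(-c3cccc(NC(=O)Nc4cc(C(F)(F)F)cc(C(F)(F)F)c4)c3)cc2-c2ccncc2)ccc1Cl`, 2170 nM
compound 3 `COc1cc(-c2nn(-c3cccc(NC(=O)Nc4cccc(C(F)(F)F)c4)c3)cc2-c2ccncc2)ccc1Cl`, 2410 nM

In a functional assay on Malme-3M cells (Homo sapiens) for inhibition, read by sulforhodamine B assay, with a stated time of 48 h (on this read-out higher numbers stand for weaker inhibition of growth and lower numbers for stronger inhibition of growth), compound 2 gives the lowest number of the three, though compound 3 sits within the scatter of it, so no order between those two can be claimed; compound 1 is the one that stands clearly apart, with a much higher number.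

Compound 4 `O=C(Nc1cccc(-n2cc(-c3ccncc3)c(-c3ccc(Cl)c(O)c3)n2)c1)Nc1cc(C(F)(F)F)cc(C(F)(F)F)c1` has not yet been measured. It differs from compound 2 in one place: hydrogen in place of methyl on an oxygen on an aromatic ring. Two of the measured steps bear on this. Among the compounds with values here, the step of an 8.3-fold lower number from compound 1 to compound 3 (0.92 log units; beyond the scatter) is the reverse of the change now made, and it is the only step beyond the scatter. The step of a 1.1-fold higher number from compound 2 to compound 3 (0.05 log units; within the scatter) shows that the second trifluoromethyl makes no difference to speak of, so compound 4 can be read as compound 1 carrying that extra group, and compound 1 gives 20100 nM.

A step of roughly that size, back towards a higher number, is therefore expected from compound 2 to compound 4, namely an 8.3-fold higher number from compound 2 to compound 4 (0.92 log units; beyond the scatter). For compound 4 the estimated value in this assay is 18000 nM, with a range from 7000 nM to 45000 nM.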

Compound 4, concentration for total growth inhibition: 3030 nM
For compound 4 the middle estimate is 5.9-fold (0.77 log units) above the measured one; the measured number lies below the stated range.
By their numbers in this assay, from the lowest: compounds 2, 3 and 4 (each within the scatter of the next); then compound 1.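

In this assay the swap of methyl for hydrogen on the oxygen gives a 1.4-fold higher number from compound 2 to compound 4 (0.14 log units; within the scatter), so the change from methoxy to hydroxy does not carry a fixed penalty, and its size depends on whether the second trifluoromethyl is present: the same change on two cores in this assay, an 8.3-fold lower number (0.92 log units; beyond the scatter) from compound 1 to compound 3 and a 1.4-fold lower number (0.14 log units; within the scatter) from compound 4 to compound 2, 6.0-fold (0.78 log units) apart, beyond the scatter of two such steps The second trifluoromethyl, which made no readable difference while the methoxy group was there, gives a 6.6-fold lower number from compound 1 to compound 4 (0.82 log units; beyond the scatter) with the hydroxy group in place, so the two changes do not add independently: the same change on two cores in this assay, a 1.1-fold higher number (0.05 log units; within the scatter) from compound 2 to compound 3 and a 6.6-fold higher number (0.82 log units; beyond the scatter) from compound 4 to compound 1, 6.0-fold (0.78 log units) apart, beyond the scatter of two such steps Among the four compounds, compound 1 alone stands apart, and it is the only one that combines the hydroxy group with a single trifluoromethyl.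

The compounds shown cover only these two changes, so they cannot tell whether the high number of compound 1 is specific to the hydroxy group or would also appear with an amine or an ethoxy group in that place. They also give no reason why the second trifluoromethyl matters only when the hydroxy group is present, and they leave open whether this dependence extends to other substituents on that ring.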